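Methoxy in Place of Fluoro on the Benzyl Ring

A few compounds are considered here, and "the series" means these few. Any claim that something is new, unique, unknown or untested is made for them only; others in the source may bear on it.

Measured compounds:
compound 1, `O=C(O)c1ccccc1-c1ccc(CCc2ncc(Cc3cccc(Cl)c3)[nH]2)cc1`, 31 nM
compound 2, `N#Cc1cccc(Cc2cnc(CCc3ccc(-c4ccccc4C(=O)O)cc3)[nH]2)c1`, 20 nM
compound 3, `O=C(O)c1ccccc1-c1ccc(CCc2ncc(Cc3cccc(F)c3)[nH]2)cc1`, 7.9 nM

The three measured compounds share one core and differ only in the group on the benzyl ring. In an in vitro functional assay on cells for agonist activity at Bombesin receptor subtype-3 (Mus musculus), read by luminescence and calcium flux (a higher number here means that more compound is needed for the effect, a lower number that less compound is needed), compound 3 gives 7.9 nM, the lowest of the three numbers. The steps to it are beyond the scatter: a 3.9-fold lower number from compound 1 to compound 3 (0.59 log units; beyond the scatter) and a 2.5-fold lower number from compound 2 to compound 3 (0.40 log units; beyond the scatter), while the gap between the other two is within it: a 1.6-fold lower number from compound 1 to compound 2 (0.19 log units; within the scatter).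

Compound 4 is `COc1cccc(Cc2cnc(CCc3ccc(-c4ccccc4C(=O)O)cc3)[nH]2)c1`. The change from compound 3 is methoxy in place of fluoro on an aromatic carbon. For the measured compounds named here, no measured step involves methoxy, so the relevant evidence is that fluoro at this position gave the lowest number and the two other groups tried there gave modestly higher ones, as seen in a 3.9-fold lower number from compound 1 to compound 3 (0.59 log units; beyond the scatter) and a 2.5-fold lower number from compound 2 to compound 3 (0.40 log units; beyond the scatter). A modest rise is therefore expected, a 2.5-fold higher number from compound 3 to compound 4 (0.40 log units; beyond the scatter). The estimate for compound 4 in this assay is 20 nM, with a range from 8 nM to 60 nM.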

Compound 4, half-maximal effective concentration: 79 nM
Beside the measured number, compound 4's estimate is 4.0-fold (0.60 log units) below it; measured number above the stated range.
By their numbers in this assay, from the lowest: compound 3; then compounds 2 and 1 (each within the scatter of the next); then compound 4.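

In this assay, methoxy stands apart from all three earlier groups at this position on the benzyl ring: the change gives a 10-fold higher number from compound 3 to compound 4 (1.00 log units; beyond the scatter) and also a 4.0-fold higher number from compound 2 to compound 4 (0.60 log units; beyond the scatter) as well as a 2.5-fold higher number from compound 1 to compound 4 (0.41 log units; beyond the scatter) in the same direction. The earlier compounds shown here showed only a narrow spread at this position, and the new step shows that the choice of group here can move the number considerably further. Nothing measured accounts for this change, which adds one heavy atom and one hydrogen-bond acceptor relative to fluoro.

The compounds shown leave open whether a methyl or a hydroxyl in the same place would fall nearer fluoro or nearer methoxy. They also leave open whether a longer chain such as ethoxy would raise the number further.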